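Solubility in a bicyclic aminopyridine series: the acid analogue

The source may hold more compounds than are shown below. What is called first, only, known or untested is meant among the compounds shown, and "the series" means these compounds.

Three members of the series share one core. Compound 1 `FC(F)(F)Oc1ccc(-c2nc3cnc(Nc4ccccn4)cc3[nH]2)cc1`, compound 2 `COc1cccnc1Nc1cc2[nH]c(-c3cccc(C(F)(F)F)c3)nc2cn1` and compound 3 `Fc1ccc(Nc2cc3[nH]c(-c4ccc(F)c(F)c4)nc3cn2)nc1` have each been run in a physicochemical assay for solubility, using the shake flask method, in phosphate buffer, measured as kinetic solubility, with a stated time of 20 h, at pH 6.5; a higher number here means a more soluble compound, a lower number a less soluble compound. For compound 1 the result is only a limit, < 5000 nM. For compound 3 the result is likewise a limit, < 5000 nM. Compound 2 also sits at a limit, < 5000 nM; the three values coincide in that every one of them is a limit (the limit of < 5000 nM in this assay, at which 3 of the 3 values shown sit), so compound 2 cannot be ranked against the others. On these data alone, compound 4 `O=C(O)c1ccnc(Nc2cc3[nH]c(-c4cccc(C(F)(F)F)c4)nc3cn2)c1` is untested. It differs from compound 2 as follows: 4-carboxypyridin-2-yl in place of 3-methoxypyridin-2-yl on a nitrogen on an aromatic ring. Within the data shown here, no measured pair isolates such a change, so the expectation rests on the change alone; an upward step an at least 4.0-fold higher number from compound 2 to compound 4 (0.60 log units; beyond the scatter) is expected, beyond the scatter. Compound 4 is estimated at 20000 nM, within 3000 nM to 150000 nM.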

Compound 4, solubility: < 5000 nM
Compound 4 ended at the assay's limit; the forecaster's own chance of this, stated with the estimate: 35%; middle value at least 4.0-fold (0.60 log units) from the limit.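

No step can be read between compound 2 and compound 4 in this assay, as both results are limits: the limit of < 5000 nM in this assay, at which 4 of the 4 values shown sit.

On these data alone, whether 4-carboxypyridin-2-yl in place of 3-methoxypyridin-2-yl changes solubility at all, and in which direction, stays open.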